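Series notes: fluoro to hydrogen, compound 2 to compound 3

The source may hold more compounds than are shown below. What is called first, only, known or untested is meant among the compounds shown, and "the series" means these compounds.

Measured so far:
compound 1 `COc1cc(OC)cc(-n2c(-c3ccccc3)nc(C)c2C)c1` gives 13.3%
compound 2 `COc1ccc(-n2c(-c3ccc(F)cc3)nc(C)c2C)cc1` gives 38.1%

In a functional assay, with a stated time of 15 min, tested at 10 uM (a lower number here means a weaker effect, a higher number a stronger effect of the compound at the concentration tested), compound 2 gives 38.1%, the higher of the two numbers; in this assay compound 1 gives 13.3%, a gap beyond the scatter. Compound 3 `COc1ccc(-n2c(-c3ccccc3)nc(C)c2C)cc1` is not yet measured. Its difference from compound 2: hydrogen in place of fluoro on an aromatic carbon. Going by the values given here, no step of this kind is known among the measured compounds, so the size is uncertain; a small loss, or none beyond the scatter, is expected. Compound 3 is expected to give 30% in this assay, within 12% to 50%. The expected step is a number 8.1 percentage points lower from compound 2 to compound 3 (within the scatter).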

Compound 3, a percentage reported as activity, at one concentration (the size of the read-out at that concentration, not a potency): 10.5%
Estimate against measurement, compound 3: 19.5 percentage points above; measured number below the stated range.
By their numbers in this assay, from the lowest: compounds 3 and 1 (each within the scatter of the next); then compound 2.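

In this assay, going by these compounds alone, the change from 4-fluorophenyl to phenyl gives a number 27.6 percentage points lower from compound 2 to compound 3 (beyond the scatter) and is the first one-place comparison. It shows that this aromatic position is sensitive to the replacement of fluoro by hydrogen, with the fluoro compound ahead. Nothing available explains the size of this step.

From the compounds shown here alone, it remains open whether the effect is specific to fluoro or would also appear with chloro, methyl, an amine or a carboxylic acid at this carbon. Going by these compounds, the same change on the methoxy pattern of compound 1 is also open.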